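Hydroxy addition and cytotoxicity in a bis-amidine series

The compounds below may be only part of what the source reports. "The series", "measured", "known", "first", "only" and "open" are said of these compounds alone.

Compound 1 `N=C(N)c1ccc(-c2cc3cc(C(=N)N)cc(O)c3o2)cc1` and compound 3 `N=C(N)c1ccc(-c2cc3cc(C(=N)N)cc(O)c3o2)c(O)c1` share a core and differ in one place: hydroxy in place of hydrogen on an aromatic carbon. In an ADME assay on L6 cells (Rattus norvegicus) for cytotoxicity (a higher number here means a weaker inhibitor, a lower number a stronger inhibitor), compound 1 gives 184000 nM. In this assay compound 3 gives 2100 nM. Within the data shown here, the step of an 88-fold lower number from compound 1 to compound 3 (1.94 log units; beyond the scatter) is the only measured step in the set.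

Compound 2 `Oc1cc(C2=NCCN2)cc2cc(-c3ccc(C4=NCCN4)cc3)oc12` carries a different core from compound 1; the difference between the two cores is not broken down here. In this assay compound 2 reaches only a limit, > 203000 nM, so its number is not known (the limit of > 203000 nM in this assay, at which 1 of the 3 values shown sits).

Compound 4 `Oc1cc(C2=NCCN2)ccc1-c1cc2cc(C3=NCCN3)cc(O)c2o1` is not yet measured. It stands to compound 2 as compound 3 stands to compound 1: hydroxy in place of hydrogen on an aromatic carbon. The two places are not the same word for word: in compound 1 the position is meta to a group of 3 heavy atoms, in compound 2 it is meta to a group of 5 heavy atoms, so the change is the same kind of change rather than the same change.

For compound 4 a step of roughly the size of an 88-fold lower number from compound 1 to compound 3 (1.94 log units; beyond the scatter) is expected, here an at least 40-fold lower number from compound 2 to compound 4 (1.60 log units; beyond the scatter), resting on that single measured step and on the limit of compound 2. Since compound 2 gives only a limit, the estimate carries a wide range. Compound 4 is expected to give about 5000 nM in this assay, between 1000 nM and 80000 nM.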

Compound 4, half-maximal inhibitory concentration: > 193000 nM
Compound 4 ended at the assay's limit; the forecaster's own chance of this, stated with the estimate: 15%; middle value at least 38-fold (1.58 log units) away from the limit.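

Compound 2 ends at a limit in this assay: the limit of > 203000 nM in this assay, at which 1 of the 4 values shown sits. Among these compounds, compound 4 also ends at a limit, so no step from compound 2 to compound 4 can be read: the limit of > 193000 nM in this assay, at which 1 of the 4 values shown sits. Left open is whether hydroxy in place of hydrogen on an aromatic carbon changes the number at all on the core of compound 2, as it does on the core of compound 1.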